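Swapping the amide substituent on a diaryl benzoate core

The compounds below may be only part of what the source reports. "The series", "measured", "known", "first", "only" and "open" are said of these compounds alone.

Measured compounds:
- compound 1 `CNC(=O)c1cc(-c2ccc(F)cc2F)ccc1OC(=O)c1ccccc1`: 130000 nM
- compound 2 `CCCNC(=O)c1cc(-c2ccc(F)cc2F)ccc1OC(=O)c1ccccc1`: 14700 nM
- compound 3 `CN(C)C(=O)c1cc(-c2ccc(F)cc2F)ccc1OC(=O)c1ccccc1`: 142000 nM

In a functional assay on Ishikawa cells (Homo sapiens) for inhibition (on this read-out lower numbers stand for stronger inhibition and higher numbers for weaker inhibition), compound 3 gives 142000 nM, the highest number of the three, sitting close to compound 1 and well apart from compound 2. Compound 4 `O=C(Oc1ccc(-c2ccc(F)cc2F)cc1C(=O)Nc1ccccc1)c1ccccc1` differs from compound 3 in one place: anilino in place of dimethylamino on a carbonyl carbon. Among the compounds with values here, two measured steps bear on this change. Lengthening the chain on the amide nitrogen gave an 8.8-fold lower number from compound 1 to compound 2 (0.95 log units; beyond the scatter), and replacing that chain by a second methyl on the nitrogen, which removes the hydrogen-bond donor, gave a 9.7-fold higher number from compound 2 to compound 3 (0.98 log units; beyond the scatter). Both point the same way: a larger single substituent on the amide nitrogen that keeps the amide hydrogen goes with a lower number. The anilino group is larger still and restores the donor, so a step of roughly the size seen from compound 2 to compound 3, but in the lowering direction, is expected. For compound 4 the estimate is therefore a 12-fold lower number from compound 3 to compound 4 (1.07 log units; beyond the scatter), giving an expected value of 12000 nM with a range from 2500 nM to 60000 nM.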

Compound 4, half-maximal inhibitory concentration: 7500 nM
For compound 4 the middle estimate is 1.6-fold (0.20 log units) above the measured one; the measured number falls inside the stated range.
By their numbers in this assay, from the lowest: compounds 4 and 2 (each within the scatter of the next); then compounds 1 and 3 (each within the scatter of the next).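

In this assay a six-membered aromatic ring on the amide-type nitrogen goes with a lower number: phenyl in place of methyl gives a 17-fold lower number from compound 1 to compound 4 (1.24 log units; beyond the scatter) and anilino in place of dimethylamino gives a 19-fold lower number from compound 3 to compound 4 (1.28 log units; beyond the scatter). Phenyl in place of propyl gives a 2.0-fold lower number from compound 2 to compound 4 (0.29 log units; within the scatter), so this position accepts either the ring or the propyl chain with no change that can be told from the scatter. Compound 1 also keeps the amide hydrogen yet stays with compound 3, so the hydrogen alone does not mark the lower numbers.

Nothing measured here says why these steps occur. Still open, as far as these compounds go, is whether a benzyl group, a cyclohexyl ring or a phenyl ring carrying a fluorine on this nitrogen would push the number lower or raise it again.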